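The source may report more compounds than this note shows. Statements on the series, on what has been measured and on what is new or still open speak of the compounds shown alone.

Measured so far in an assay on isolated protein for inhibition of phosphodiesterase 4A (Sus scrofa); a lower number here means a stronger inhibitor, a higher number a weaker inhibitor:
- compound 2 `COc1ccc(C(=O)Nc2cnccn2)cc1OC1CCCC1`: 250 nM
- compound 1 `COc1ccc(C(=O)Nc2ccccc2F)cc1OC1CCCC1`: 10700 nM

Compound 2 holds the lowest number of the two; its nearest neighbour is compound 1, and the step of a 43-fold lower number from compound 1 to compound 2 (1.63 log units; beyond the scatter) separates them. That single step is the only one available, and it bears directly on the present case: both changes sit on the same amide-type nitrogen, and the replacement of one substituent by another there moved this assay by a large amount.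

Compound 3 `COc1ccc(C(=O)NC2(C)C=C(C)ON2)cc1OC1CCCC1` is not yet measured. The change a group of 7 heavy atoms (5 carbon, 1 nitrogen, 1 oxygen; one five-membered non-aromatic ring with 2 hetero atoms) in place of a group of 6 heavy atoms (4 carbon, 2 nitrogen; one six-membered aromatic ring with 2 hetero atoms), on an amide-type nitrogen removes the group that carried compound 2 to its low number and puts in a non-aromatic ring with a hydrogen-bond donor. Given how strongly this position responded from compound 1 to compound 2, a step beyond the scatter is expected, most likely toward a higher number. Compound 3 is therefore estimated at 3000 nM (range 600 nM to 15000 nM), a step of a 12-fold higher number from compound 2 to compound 3 (1.08 log units; beyond the scatter).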

Compound 3, half-maximal inhibitory concentration: 450 nM
Compound 3: the middle estimate sits 6.7-fold (0.82 log units) above what was measured; measured number outside the range, below it.
By their numbers in this assay, from the lowest: compounds 2 and 3 (each within the scatter of the next); then compound 1.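

In this assay the reading a 1.8-fold higher number from compound 2 to compound 3 (0.26 log units; within the scatter) shows that on this amide-type nitrogen a five-membered non-aromatic ring with 2 hetero atoms cannot be told apart from pyrazin-2-yl, so an aromatic ring here is not needed to reach the range of compound 2. The second reading, a 24-fold lower number from compound 1 to compound 3 (1.38 log units; beyond the scatter), is large, like a 43-fold lower number from compound 1 to compound 2 (1.63 log units; beyond the scatter), which leaves compound 1 alone at the high end while two quite different rings sit together at the low end. No measurement on hand accounts for this.

The compounds shown leave open whether a cyclohexyl or pyridin-2-yl group on this nitrogen would stay with compound 2 and compound 3 or fall with compound 1. They also leave open whether the hetero atoms in these rings matter at all, since no ring of carbon only other than the 2-fluorophenyl of compound 1 appears.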